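The compounds below may be only part of what the source reports. "The series", "measured", "known", "first", "only" and "open" are said of these compounds alone.

Three compounds share one core and differ only in the group on an amine nitrogen in a ring. Compound 1 `N#Cc1cccc(COc2ccc(-c3cc(CN4CCN(c5ccc(C(F)(F)F)cc5)CC4)no3)cc2)c1` carries a 4-(trifluoromethyl)phenyl there, compound 2 `N#Cc1cccc(COc2ccc(-c3cc(CN4CCN(Cc5cccc(F)c5)CC4)no3)cc2)c1` a 3-fluorobenzyl, and compound 3 `N#Cc1cccc(COc2ccc(-c3cc(CN4CCN(C(=O)C5CCCO5)CC4)no3)cc2)c1` an (oxolan-2-yl)carbonyl. In a functional assay on Mahlavu cells (Homo sapiens) for antiproliferative activity, read by sulforhodamine B assay, with a stated time of 72 h (on this read-out lower numbers stand for stronger inhibition and higher numbers for weaker inhibition), compound 1 gives 2700 nM, compound 2 gives 2600 nM, and compound 3 gives 4100 nM. Compound 3 thus has the highest of the three numbers, but the steps to it are small: a 1.5-fold higher number from compound 1 to compound 3 (0.18 log units; within the scatter) and a 1.6-fold higher number from compound 2 to compound 3 (0.20 log units; within the scatter), both within the scatter, just as a 1.0-fold lower number from compound 1 to compound 2 (0.02 log units; within the scatter) is. The unmeasured compound 4 `N#Cc1cccc(COc2ccc(-c3cc(CN4CCN(C(=O)C5CC5)CC4)no3)cc2)c1` keeps the carbonyl on that nitrogen and changes only the ring attached to it: cyclopropyl in place of oxolan-2-yl on a carbonyl carbon. Going by the values given here, no measured pair tests this exact exchange. Among the compounds with values here, the three measured steps show only that swapping one group for another on that nitrogen moved this assay by amounts within the scatter, so there is no ground to expect a shift beyond it here. Staying near the level of compound 3 is therefore expected, the estimated step being a 1.0-fold lower number from compound 3 to compound 4 (0.01 log units; within the scatter). For compound 4 in this assay the estimate is 4000 nM, with a range from 2000 nM to 8000 nM.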

Compound 4, half-maximal inhibitory concentration: 4400 nM
For compound 4 the middle estimate is 1.1-fold (0.04 log units) below the measured one; measured number inside the range.
By their numbers in this assay, from the lowest: compounds 2, 1, 3 and 4 (each within the scatter of the next).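

In this assay, going by these compounds alone, exchanging oxolan-2-yl, a five-membered ring with one hydrogen-bond acceptor, for cyclopropyl, a three-membered carbon ring with none, on a carbonyl carbon gives a small step (a 1.1-fold higher number from compound 3 to compound 4 (0.03 log units; within the scatter)), so this is the first direct look at the ring on the carbonyl rather than the whole group on the nitrogen, and it separates the two compounds by no more than the scatter. The steps that replace a group without this carbonyl are also small (a 1.7-fold higher number from compound 2 to compound 4 (0.23 log units; within the scatter); a 1.6-fold higher number from compound 1 to compound 4 (0.21 log units; within the scatter)), so the 3-fluorobenzyl, 4-(trifluoromethyl)phenyl, (oxolan-2-yl)carbonyl and cyclopropylcarbonyl compounds cannot be told apart in this assay. The data shown offer no explanation for why these different groups give such similar results.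

As far as these compounds go, it remains open whether any group on this nitrogen can take the number beyond the scatter, for instance a carboxylic acid or a longer chain ending in an amine. From the compounds shown here alone, all four compounds also share the same core, so what a change elsewhere, such as replacing the nitrile, would do remains unknown.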